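The compounds below may be only part of what the source reports. "The series", "measured", "known", "first", "only" and "open" are said of these compounds alone.

Among the measured compounds shown here, compound 2 `COc1cc(-c2nn(-c3cccc(NC(=O)Nc4cccc(C(F)(F)F)c4)c3)cc2-c2ccncc2)ccc1Cl` stands at the lower end of the two numbers measured so far: in a functional assay on SK-MEL-5 cells (Homo sapiens) for inhibition, read by sulforhodamine B assay, with a stated time of 48 h (on this read-out higher numbers stand for lower toxicity in this test and lower numbers for higher toxicity in this test), compound 2 gives 2680 nM, whereas compound 1 `COc1cc(-c2nn(-c3cccc(NC(=O)c4cccc(C(F)(F)F)c4)c3)cc2-c2ccncc2)ccc1Cl` gives 40600 nM. For the measured compounds named here, the only step recorded is a 15-fold lower number from compound 1 to compound 2 (1.18 log units; beyond the scatter), the replacement of a 3-(trifluoromethyl)phenyl group by a (3-(trifluoromethyl)phenyl)amino group on a carbonyl carbon. Compound 3 `COc1cc(-c2nn(-c3cccc(NC(=O)c4ccccc4)c3)cc2-c2ccncc2)ccc1Cl` reverses part of that change and goes further: phenyl in place of (3-(trifluoromethyl)phenyl)amino on a carbonyl carbon. Because the step of a 15-fold lower number from compound 1 to compound 2 (1.18 log units; beyond the scatter) was large, undoing the amino link is expected to raise the number again, and nothing measured tells how the loss of the trifluoromethyl group acts on its own. A rise of roughly a 19-fold higher number from compound 2 to compound 3 (1.27 log units; beyond the scatter) is therefore expected for compound 3 in this assay. The number for compound 3 is estimated at 50000 nM, within a range from 15000 nM to 150000 nM.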

Compound 3, concentration lethal to 50% of the cells: 7100 nM
The estimate for compound 3 lay 7.0-fold (0.85 log units) above the measured number; measured number outside the range, below it.
By their numbers in this assay, from the lowest: compound 2; then compound 3; then compound 1.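

In this assay the trifluoromethyl group turns out to matter on its own: hydrogen in its place on the aromatic carbon gives a 5.7-fold lower number from compound 1 to compound 3 (0.76 log units; beyond the scatter) and so, without any amino link, the number falls and toxicity in this test rises. Phenyl in place of (3-(trifluoromethyl)phenyl)amino on the carbonyl carbon gives a 2.6-fold higher number from compound 2 to compound 3 (0.42 log units; beyond the scatter) and so leaves compound 3 nearer to compound 2 than to compound 1, which means the amino link is not the only route to a lower number here. No measurement is at hand to explain either step. The compounds shown leave open how the amino link acts when no trifluoromethyl group is present. They also leave open whether a methyl group, a chlorine atom or a methoxy group in place of trifluoromethyl would behave like hydrogen.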